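From 3,4-difluorophenyl to 4-fluorophenyl on the sulfonyl sulfur

The source may report more compounds than this note shows. Statements on the series, on what has been measured and on what is new or still open speak of the compounds shown alone.

In an ADME assay on microsomes from liver (Mus musculus) for metabolic stability, read by LC-MS, with a stated time of 30 min, tested at 1 uM (a higher number here means that more of the compound is left, a lower number that less of the compound is left), compound 1 `O=C(NCc1ccc(S(=O)(=O)c2cc(F)cc(F)c2)cc1)c1cc2cnccc2[nH]1` gives 63% and compound 2 `O=C(NCc1ccc(S(=O)(=O)c2ccc(F)c(F)c2)cc1)c1cc2cnccc2[nH]1` gives 58%, which places these two within the scatter of each other. Compound 3 `O=C(NCc1ccc(S(=O)(=O)c2ccc(F)cc2)cc1)c1cc2cnccc2[nH]1` differs from compound 2 by hydrogen in place of fluoro on an aromatic carbon. Going by the values given here, the only measured step nearby is a number 5 percentage points lower from compound 1 to compound 2 (within the scatter), and it relocates a fluoro rather than removing one, so it is an imperfect guide. In this assay, no change beyond the scatter is expected, and the estimated move is a number 2 percentage points higher from compound 2 to compound 3 (within the scatter). The estimate for compound 3 is 60%, with an expected range of 45% to 74%.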

Compound 3, percent of the compound remaining: 72%
For compound 3 the middle estimate is 12 percentage points below the measured one; measured number inside the range.
By their numbers in this assay, from the lowest: compounds 2, 1 and 3 (each within the scatter of the next, the first and the last beyond it).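

In this assay, going by these compounds alone, hydrogen in place of the fluoro ortho to a fluoro group and meta to a large group gives a number 14 percentage points higher from compound 2 to compound 3 (beyond the scatter) and is the first step to pass the scatter. The comparison with the 3,5-difluorophenyl group gives a number 9 percentage points higher from compound 1 to compound 3 (within the scatter) and stays within the scatter, so the clear difference holds only against the 3,4-difluorophenyl group. No measurement shown here explains the step.

Whether the remaining fluoro matters is open. A plain phenyl, a 4-chlorophenyl or a 4-methoxyphenyl on the sulfonyl sulfur would address this.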